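Cyclopropyl amides on the shared core: methyl for fluorine

This account rests on a few compounds, and the source may have more. Where it says the series, first, only, none or still open, it means among the compounds named here.

Among the compounds with values here, in an assay on CHO cells for displacement of a labelled ligand from Neuronal acetylcholine receptor; alpha3/alpha6/beta2/beta3 (Homo sapiens), read by scintillation counting (a lower number here means a stronger inhibitor, a higher number a weaker inhibitor), compound 3 `O=C([C@@H]1C[C@@H]1F)N1CC2CC(C1)N2` gives 55 nM and stands second highest of the three numbers so far. Compound 2 `O=C([C@H]1C[C@H]1F)N1CC2CC(C1)N2` gives 27 nM in this assay; the two differ only in drawn configuration, the step of a 2.0-fold higher number from compound 2 to compound 3 (0.31 log units; beyond the scatter) is modest, and the fact that one of compounds 2 and 3 is drawn with a defined configuration and the other without, at the place where they differ bears on how that pair is drawn. Compound 1 `CC(C)C(=O)N1CC2CC(C1)N2`, with isopropyl on the carbonyl carbon, gives 580 nM in this assay; the steps of a 21-fold lower number from compound 1 to compound 2 (1.33 log units; beyond the scatter) and an 11-fold lower number from compound 1 to compound 3 (1.02 log units; beyond the scatter) are both large.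

Compound 4 `C[C@@H]1C[C@@H]1C(=O)N1CC2CC(C1)N2` differs from compound 3 by a group of 4 heavy atoms (4 carbon; one three-membered non-aromatic ring of carbon only) in place of a group of 4 heavy atoms (3 carbon, 1 fluorine; one three-membered non-aromatic ring of carbon only), on a carbonyl carbon. Within the data shown here, no measured step exchanges fluorine for carbon on the three-membered ring; the nearest guide is the move from isopropyl to 2-fluorocyclopropyl, which went with the large steps from compound 1. Compound 4 keeps the three-membered ring, so its number is expected to lie between those of compound 1 and compound 3, nearer compound 3. For compound 4 the expected step is a 2.4-fold higher number from compound 3 to compound 4 (0.37 log units; beyond the scatter). Compound 4 is estimated at 130 nM, with a range from 45 nM to 400 nM.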

Compound 4, inhibition constant: 92 nM
Compound 4: the middle estimate sits 1.4-fold (0.15 log units) above what was measured; the range from low to high includes it.
By their numbers in this assay, from the lowest: compound 2; then compounds 3 and 4 (each within the scatter of the next); then compound 1.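

In this assay, within the data shown here, the three-membered ring without fluorine still improves on isopropyl, with a 6.3-fold lower number from compound 1 to compound 4 (0.80 log units; beyond the scatter) as the step, so 2-fluorocyclopropyl is not the only group on the carbonyl carbon that does so. Methyl in place of fluoro on a saturated ring carbon gives the first measured exchange at that ring atom, and it costs affinity, with a 3.4-fold higher number from compound 2 to compound 4 (0.53 log units; beyond the scatter) as the step. Against compound 3 the picture is flatter: the step of a 1.7-fold higher number from compound 3 to compound 4 (0.22 log units; within the scatter) sets no order between the two.

Going by these compounds, whether a hydroxyl, a nitrile or an amine on that ring carbon would hold these numbers remains open. Among these compounds, the only evidence at hand concerns how compounds 2 and 3 are drawn, and it does not bear on the exchange of fluorine for methyl.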